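From compound 1 to compound 4: a ring exchange

The source may hold more compounds than are shown below. What is called first, only, known or untested is meant among the compounds shown, and "the series" means these compounds.

Measured compounds so far:
compound 1 `Cc1cc(C(=O)NNS(=O)(=O)c2ccccc2F)cc(-c2ccccn2)c1`, 12.5 ug/mL
compound 2 `O=C(NNS(=O)(=O)c1ccccc1F)c1cccc(-c2ccccn2)c1`, 12.5 ug/mL
compound 3 `Cc1cc(-c2ccccn2)cc(C(=O)NNS(=O)(=O)c2ccccc2)c1F`, 6.3 ug/mL

All three were read in a physicochemical assay for solubility, read by nephelometry, in phosphate buffer, measured as kinetic solubility, at pH 6.5; on this read-out higher numbers stand for higher solubility and lower numbers for lower solubility. Compound 1 stands level with compound 2 at the digits shown, and the two together hold the highest number of the three; compound 3 lies a little lower, but its gap to compound 1 is within the scatter, so no order among the three can be claimed. Within the data shown here, the only single-point step among them, no change at the digits printed from compound 1 to compound 2 (within the scatter), shows that removing the methyl group left the read-out unchanged.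

Compound 4 `Cc1cc(C(=O)NNS(=O)(=O)c2ccccc2F)cc(-c2ccco2)c1` differs from compound 1 in one place: furan-2-yl in place of pyridin-2-yl on an aromatic carbon. Neither measured step bears on this change directly. The step from compound 1 to compound 2 touches a methyl group, not the pyridin-2-yl ring, and compound 3 differs from compound 1 in more than one place. The data therefore give no measured anchor for exchanging pyridin-2-yl for furan-2-yl, and the expectation must stay loose. A small downward step, a 2.0-fold lower number from compound 1 to compound 4 (0.30 log units; within the scatter), is estimated, but one that may well fall within the scatter. Compound 4 is expected to give about 6.3 ug/mL, with a range from 2.5 ug/mL to 15 ug/mL.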

Compound 4, solubility: 6.3 ug/mL
For compound 4 middle estimate and measured number coincide at the digits printed; the measured number falls inside the stated range.
By their numbers in this assay, from the lowest: compounds 3, 4, 1 and 2 (each within the scatter of the next).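

In this assay, compounds 1, 2 and 3 all carry pyridin-2-yl, so they say nothing about this ring, whereas the exchange for furan-2-yl gives a 2.0-fold lower number from compound 1 to compound 4 (0.30 log units; within the scatter). Among these compounds, this is the first reading at this place, on an aromatic carbon meta to a large group and meta to a methyl group, and it shows that a five-membered aromatic ring with oxygen as its hetero atom and a six-membered aromatic ring with nitrogen as its hetero atom cannot be told apart on this read-out, at least in this one pair on the core of compound 1. Nothing measured here speaks to why the two rings read alike.

As far as these compounds go, it remains open whether the same holds for a group of another kind at this place, such as a morpholine ring, a primary amine or a carboxylic acid, any of which might move the read-out beyond the scatter. From the compounds shown here alone, it is also open whether furan-2-yl would read the same way on the core of compound 2, with hydrogen in place of the methyl group.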